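This account rests on a few compounds, and the source may have more. Where it says the series, first, only, none or still open, it means among the compounds named here.

Four compounds share one core, and they differ only in the groups hung on it. Among the measured compounds shown here, compound 1 `O=C1NC(O)(CCn2cc(-c3ccccc3)nn2)C(OCc2ccccc2)=C1OCc1ccccc1` is the first of them; in a functional assay on HCT-116 cells (Homo sapiens) for antiproliferative activity, read by MTT assay, with a stated time of 24 h (on this read-out higher numbers stand for weaker inhibition and lower numbers for stronger inhibition), compound 1 gives 53400 nM. Compound 2 `CC(C)(C)c1ccc(-c2cn(CCC3(O)NC(=O)C(OCc4ccccc4)=C3OCc3ccccc3)nn2)cc1` differs from compound 1 by a single change, (tert-butyl in place of hydrogen on an aromatic carbon). In this assay compound 2 reaches the limit of the assay, > 100000 nM, so no number is known for it. The step of an at least 1.8-fold higher number from compound 1 to compound 2 (0.27 log units; that floor lies within the scatter) can therefore be stated only as a floor, because of the limit of > 100000 nM in this assay, at which 1 of the 3 values shown sits. Compound 3 `COC1=C(OC)C(O)(CCn2cc(-c3ccccc3)nn2)NC1=O` carries a different set of groups on the core, and the difference between the core of compound 1 and the core of compound 3 is not broken down here. In this assay compound 3 gives 46300 nM, a value that lies within the usual scatter of the value of compound 1, so the two cannot be told apart. Compound 4 `COC1=C(OC)C(O)(CCn2cc(-c3ccc(C(C)(C)C)cc3)nn2)NC1=O` stands to compound 3 exactly as compound 2 stands to compound 1: it is made by the same change, (tert-butyl in place of hydrogen on an aromatic carbon), at the same kind of place. What can be expected of compound 4 rests on that one measured pair, since the change from compound 1 to compound 2 gave an at least 1.8-fold higher number from compound 1 to compound 2 (0.27 log units; that floor lies within the scatter), and a step of similar size is expected here, a 2.4-fold higher number from compound 3 to compound 4 (0.38 log units; beyond the scatter). For compound 4 the estimated value in this assay is 110000 nM, expected to lie between 50000 nM and 300000 nM, with a real chance that only a limit is reported.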

Compound 4, half-maximal inhibitory concentration: 50300 nM
Compound 4: middle estimate off by 2.2-fold (0.34 log units), on the high side, within the range that was stated.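

In this assay, putting a tert-butyl group on the aromatic ring of the core of compound 3 gives a 1.1-fold higher number from compound 3 to compound 4 (0.04 log units; within the scatter) and so, on this core, the change cannot be told apart from no change at all. On the other core the same change ends at a limit of the assay: compound 2 gives > 100000 nM as a limit and not as a number. The two steps therefore show no clear effect of tert-butyl on either core, yet they do not prove that the change behaves alike on both, since the true size of the first step stays unknown: the same change on two cores in this assay, an at least 1.8-fold higher number (0.27 log units; that floor lies within the scatter) from compound 1 to compound 2 and a 1.1-fold higher number (0.04 log units; within the scatter) from compound 3 to compound 4; the limit leaves it open whether they differ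

Among the compounds shown here, with only one pair on each core, no general rule about this change can be drawn for the series. The compounds shown leave open whether a different group on that aromatic carbon, such as an amine, a carboxylic acid or a longer chain, would shift the number in this assay beyond the usual scatter. They also leave open how the tert-butyl change would fare on a core carrying other groups, for example a hydroxyl or an amine, in place of those on the two cores seen here.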